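The source may report more compounds than this note shows. Statements on the series, on what has been measured and on what is new or still open speak of the compounds shown alone.

Of the compounds shown here, two that share one core have so far been tested in an assay for inhibition of 3-hydroxy-3-methylglutaryl-coenzyme A reductase (Rattus norvegicus); on this read-out lower numbers stand for stronger inhibition and higher numbers for weaker inhibition. Compound 1 `CCCCC(=O)O[C@H]1C[C@@H](C)C=C2C=C[C@H](C)[C@H](CC[C@@H]3C[C@@H](O)CC(=O)O3)C21` gives 8.7 nM. Going by the values given here, compound 2 `C=C(C)CC(=O)O[C@H]1C[C@@H](C)C=C2C=C[C@H](C)[C@H](CC[C@@H]3C[C@@H](O)CC(=O)O3)C21` gives 2.9 nM, the lowest of the two numbers; the only measured step is a 3.0-fold lower number from compound 1 to compound 2 (0.48 log units; beyond the scatter). Compound 3 `CC(CC(=O)O[C@H]1C[C@@H](C)C=C2C=C[C@H](C)[C@H](CC[C@@H]3C[C@@H](O)CC(=O)O3)C21)C(F)(F)F` carries 1-(trifluoromethyl)ethyl in place of 1-methylethenyl on a saturated chain carbon bound to a carbonyl carbon. That measured step bears on compound 3 only loosely: it swapped one small group for another on the same saturated chain carbon and moved the number modestly, whereas compound 3 brings in a saturated, fluorinated group where compound 2 has a double bond. Such a change has no measured precedent here, so the expectation rests on the observation that the two groups tried so far sit close together. The step expected from compound 2 to compound 3 is a 1.7-fold higher number from compound 2 to compound 3 (0.24 log units; within the scatter), a small drift toward a higher number. Compound 3 is estimated at 5 nM, within a range from 1.5 nM to 15 nM.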

Compound 3, half-maximal inhibitory concentration: 3.5 nM
Compound 3: the middle estimate sits 1.4-fold (0.15 log units) above what was measured; the measured number falls inside the stated range.
By their numbers in this assay, from the lowest: compounds 2 and 3 (each within the scatter of the next); then compound 1.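

In this assay, the saturated 1-(trifluoromethyl)ethyl group, with 6 heavy atoms, replaces the 1-methylethenyl group, with 3 heavy atoms and a double bond, and the result is a 1.2-fold higher number from compound 2 to compound 3 (0.08 log units; within the scatter). So on this saturated chain carbon bound to a carbonyl carbon, neither the double bond nor the smaller size is needed to keep the number where compound 2 put it. Measured against propyl, the new group gives a 2.5-fold lower number from compound 1 to compound 3 (0.40 log units; beyond the scatter), so both groups tried in place of propyl give lower numbers, although nothing shown explains why.

The compounds shown leave open whether the fluorine atoms matter at all, which a plain 1-methylethyl group in this place could test. They also leave open how far this tolerance extends, for example to a longer chain, an amine or a carboxylic acid.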